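The source may report more compounds than this note shows. Statements on the series, on what has been measured and on what is new or still open speak of the compounds shown alone.

Three compounds have been measured in an in vitro assay on CHO-KI cells for displacement of a labelled ligand from prostaglandin F2-alpha receptor (Homo sapiens); a higher number here means a weaker inhibitor, a lower number a stronger inhibitor:
compound 1, `O=C(O)CCCCCC[C@@H]1[C@@H](CC[C@@H](O)CCc2ccc(F)cc2)[C@H](O)C[C@@H]1O`, gives 210 nM;
compound 2, `O=C(O)CCCCCC[C@@H]1[C@@H](CC[C@@H](O)CCc2ccc(C(F)(F)F)cc2)[C@H](O)C[C@@H]1O`, gives 3630 nM;
compound 3, `Cc1ccc(CC[C@H](O)CC[C@@H]2[C@@H](CCCCCCC(=O)O)[C@@H](O)C[C@H]2O)cc1`, gives 4400 nM.

Compound 3 carries the highest number of the three, but its gap to compound 2, a 1.2-fold higher number from compound 2 to compound 3 (0.08 log units; within the scatter), lies within the scatter; only compound 1 stands clearly lower, by a 21-fold higher number from compound 1 to compound 3 (1.32 log units; beyond the scatter). Compound 4, `COc1ccccc1CC[C@H](O)CC[C@@H]1[C@@H](CCCCCCC(=O)O)[C@@H](O)C[C@H]1O`, differs from compound 3 by 2-methoxyphenyl in place of 4-methylphenyl on a saturated chain carbon, three bonds along the chain from an oxygen on a saturated carbon. For the measured compounds named here, no measured step makes this exact change. The steps of a 21-fold higher number from compound 1 to compound 3 (1.32 log units; beyond the scatter) and a 17-fold higher number from compound 1 to compound 2 (1.24 log units; beyond the scatter) show that swapping the group on the aromatic ring can shift this assay by a large amount, whereas a 1.2-fold higher number from compound 2 to compound 3 (0.08 log units; within the scatter) shows it can also leave the number unchanged. The direction here cannot be read from those steps, so only a modest downward step is expected, a 2.9-fold lower number from compound 3 to compound 4 (0.47 log units; beyond the scatter), with wide uncertainty. Compound 4 is therefore estimated at 1500 nM, within 250 nM to 9000 nM.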

Compound 4, half-maximal inhibitory concentration: 5890 nM
Compound 4: middle estimate off by 3.9-fold (0.59 log units), on the low side; low and high end bracket the measured number.
By their numbers in this assay, from the lowest: compound 1; then compounds 2, 3 and 4 (each within the scatter of the next).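

In this assay, 2-methoxyphenyl falls in with the two weaker aromatic groups, with a 1.3-fold higher number from compound 3 to compound 4 (0.13 log units; within the scatter) and a 1.6-fold higher number from compound 2 to compound 4 (0.21 log units; within the scatter) both small, while a 28-fold higher number from compound 1 to compound 4 (1.45 log units; beyond the scatter) is large. Adding an oxygen-bearing group at this position therefore still leaves 4-fluorophenyl as the only one of the four that stands apart. No measurement here explains why.

From the compounds shown here alone, it remains open whether 4-chlorophenyl or unsubstituted phenyl would sit near compound 1 or join the other three. 4-Methoxyphenyl could also show whether the methoxy group itself or its place on the ring matters.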